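Working notes on the chain at the aromatic nitrogen

The source may report more compounds than this note shows. Statements on the series, on what has been measured and on what is new or still open speak of the compounds shown alone.

Of the compounds shown here, three carry numbers so far. Compound 1 `COCCCn1cc(C(=O)Nc2ccc(-c3cn(C)c4ncnc(N)c34)cc2)c(=O)c(-c2ccc(F)cc2)c1` bears a 2-methoxyethyl on the saturated chain carbon bound to the aromatic nitrogen, and in an assay on isolated protein for inhibition of tyrosine-protein kinase receptor UFO (Homo sapiens), read by ELISA (a higher number here means a weaker inhibitor, a lower number a stronger inhibitor), compound 1 gives only a limit of the assay, > 10 nM, not a number. Compound 2 `Cn1cc(-c2ccc(NC(=O)c3cn(CC4CCOCC4)cc(-c4ccc(F)cc4)c3=O)c(Cl)c2)c2c(N)ncnc21` gives 3.7 nM in this assay. Compound 3 `CN(C)C(=O)Cn1cc(C(=O)Nc2ccc(-c3cn(C)c4ncnc(N)c34)cc2)c(=O)c(-c2ccc(F)cc2)c1` gives 0.5 nM in this assay, the lowest of the two numbers shown, with compound 2 standing higher by a gap beyond the scatter. Among the measured compounds shown here, the only single-point step measured, an at least 20-fold lower number from compound 1 to compound 3 (1.30 log units; beyond the scatter), is anchored on one side by a limit, (the limit of > 10 nM in this assay, at which 1 of the 3 values shown sits), so its size is a floor rather than a fixed figure.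

Compound 4 `Cn1cc(C(=O)Nc2ccc(-c3cn(C)c4ncnc(N)c34)cc2)c(=O)c(-c2ccc(F)cc2)c1` differs from compound 3 by hydrogen in place of dimethylcarbamoyl on a saturated chain carbon bound to an aromatic nitrogen. The group removed here is the very one whose arrival marked an at least 20-fold lower number from compound 1 to compound 3 (1.30 log units; beyond the scatter), which makes this position the one place in the series where a large movement has already been seen. Trimming the chain of compound 4 back to a bare methyl is therefore expected to weaken inhibition, with a 10-fold higher number from compound 3 to compound 4 (1.00 log units; beyond the scatter) as the expected step. Compound 4 is estimated at 5 nM, with a range from 1 nM to 30 nM.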

Compound 4, half-maximal inhibitory concentration: 5 nM
Compound 4: middle estimate and measured number agree at the digits printed; low and high end bracket the measured number.
By their numbers in this assay, from the lowest: compound 3; then compounds 2 and 4 (each within the scatter of the next). At a limit, above all of these: compound 1.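

With the bare methyl of compound 4 as a reference, the dimethylcarbamoyl on the saturated chain carbon bound to the aromatic nitrogen shows a gain of its own in this assay: its removal gives a 10-fold higher number from compound 3 to compound 4 (1.00 log units; beyond the scatter). The earlier step could not separate a gain from the dimethylcarbamoyl from a loss caused by the 2-methoxyethyl, whereas this one shows that the low number of compound 3 does not depend on the comparison with compound 1 alone. The other new step, an at least 2.0-fold lower number from compound 1 to compound 4 (0.30 log units; that floor lies within the scatter), sets no order between the 2-methoxyethyl and hydrogen at this place, and compound 1 remains a limit, so the step is only a floor: the limit of > 10 nM in this assay, at which 1 of the 4 values shown sits.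

Still open, on these data alone, is which part of the dimethylcarbamoyl carries the gain, a question that a primary amide, a methyl ketone or a carboxylic acid on the same chain carbon would address. Also open, as far as these compounds go, is whether the gain survives in a longer chain ending in the dimethylcarbamoyl, or with an amine such as dimethylamino at the end of the chain.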